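A few compounds are considered here, and "the series" means these few. Any claim that something is new, unique, unknown or untested is made for them only; others in the source may bear on it.

Working notes on the phenoxyphenoxy ketone series. Compound 1 `O=C(COc1ccc(Oc2ccccc2)cc1)Cn1ncc2ccccc21` carries no substituent on the core and in an assay on microsomes from brain for inhibition of Fatty-acid amide hydrolase 1 (Rattus norvegicus), read by fluorescence and HPLC, with a stated time of 45 min (a higher number here means a weaker inhibitor, a lower number a stronger inhibitor), compound 1 gives 2600 nM. Compound 2 `CC(=O)Nc1ccc2c(cnn2CC(=O)COc2ccc(Oc3ccccc3)cc2)c1` adds an acetamido group to an aromatic carbon, and in this assay compound 2 gives 3900 nM. Compound 3 `COCC(=O)Nc1ccc2c(cnn2CC(=O)COc2ccc(Oc3ccccc3)cc2)c1` carries the ((methoxymethyl)carbonyl)amino group in the same place, and in this assay compound 3 gives 6300 nM, the highest of the three numbers. The steps show a 1.5-fold higher number from compound 1 to compound 2 (0.18 log units; within the scatter) and a 2.4-fold higher number from compound 1 to compound 3 (0.38 log units; beyond the scatter), with a 1.6-fold higher number from compound 2 to compound 3 (0.21 log units; within the scatter); substitution at this aromatic carbon has so far shifted the number only slightly upward.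

Compound 4 `O=C(COc1ccc(Oc2ccccc2)cc1)Cn1ncc2cc(NC(=O)Oc3ccccc3)ccc21` continues the same change: phenoxy in place of methoxymethyl on a carbonyl carbon. For the measured compounds named here, no measured step swaps the chain on this carbonyl carbon for a ring, so the two relevant comparisons are the small effects of varying the chain (compound 2 to compound 3) and of adding the substituent at all (compound 1 to compound 3). On that basis the step is expected to stay small, a 2.5-fold lower number from compound 3 to compound 4 (0.40 log units; beyond the scatter), with wide uncertainty because a phenoxy group is a larger change than any tried here. For compound 4 in this assay the expected value is 2500 nM, estimated to lie between 250 nM and 15000 nM.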

Compound 4, half-maximal inhibitory concentration: 2100 nM
Beside the measured number, compound 4's estimate is 1.2-fold (0.08 log units) above it; the measured number falls inside the stated range.
By their numbers in this assay, from the lowest: compounds 4, 1, 2 and 3 (each within the scatter of the next, the first and the last beyond it).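

For the compounds shown here, at this carbonyl carbon, exchanging the chain for a group that brings in a six-membered aromatic ring gives a 3.0-fold lower number from compound 3 to compound 4 (0.48 log units; beyond the scatter), the only step so far that lowers the number beyond the scatter. The other two steps stay within the scatter, with a 1.9-fold lower number from compound 2 to compound 4 (0.27 log units; within the scatter) and a 1.2-fold lower number from compound 1 to compound 4 (0.09 log units; within the scatter), so in this assay the (phenoxycarbonyl)amino group, with its 7-heavy-atom phenoxy, does not separate compound 4 from the core of compound 1. No evidence on the reason for these results is available.

The compounds shown leave open whether the ring needs the oxygen linking it to the carbonyl carbon, which a benzyl or phenylamino group in place of phenoxy would test. Also open, as far as these compounds go, is how a carboxylic acid or an amine on that ring, or a longer chain in place of phenoxy, would read in this assay.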